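Compound 3 and a Carbonyl Swap at Oxygen

The source may hold more compounds than are shown below. What is called first, only, known or untested is meant among the compounds shown, and "the series" means these compounds.

Measured in a functional assay on DU-145 cells (Homo sapiens) for cytotoxicity, read by MTT assay; on this read-out lower numbers stand for stronger inhibition and higher numbers for weaker inhibition:
- compound 1 `CCCCC(CC(=O)O[C@H](CC=C(C)C)C1=CC(=O)c2c(O)ccc(O)c2C1=O)OC(C)=O`: 67700 nM
- compound 2 `CC(C)=CC[C@@H](OC(=O)C1CCOC1)C1=CC(=O)c2c(O)ccc(O)c2C1=O`: 47500 nM
- compound 3 `CC(=O)OC(C)CO[C@H](CC=C(C)C)C1=CC(=O)c2c(O)ccc(O)c2C1=O`: 16600 nM

Of these three, compound 3 has the lowest number, at 16600 nM. The next compound, compound 4 `CC[C@@](C)(O)CC(=O)O[C@H](CC=C(C)C)C1=CC(=O)c2c(O)ccc(O)c2C1=O`, differs from it thus: (2-hydroxy-2-methylbutyl)carbonyl in place of 2-acetoxypropyl on an oxygen on a saturated carbon. A carbonyl therefore stands on that oxygen again, as in compound 2. Going by the values given here, two measured steps bear on this. Running the opposite way, a 2.9-fold lower number from compound 2 to compound 3 (0.46 log units; beyond the scatter) was modest. With a change on the carbonyl carbon, a 1.4-fold lower number from compound 1 to compound 2 (0.15 log units; within the scatter) stayed within the scatter. A partial return towards higher numbers is therefore expected in this assay. The expected change is a 2.1-fold higher number from compound 3 to compound 4 (0.32 log units; beyond the scatter). For compound 4 the estimate is 35000 nM, with an expected range of 13000 nM to 85000 nM.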

Compound 4, half-maximal inhibitory concentration: 12700 nM
Compound 4: middle estimate off by 2.8-fold (0.44 log units), on the high side, and the stated range ends above it.
By their numbers in this assay, from the lowest: compounds 4 and 3 (each within the scatter of the next); then compounds 2 and 1 (each within the scatter of the next).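

In this assay, a carbonyl on this oxygen does not by itself bring higher numbers (a 1.3-fold lower number from compound 3 to compound 4 (0.12 log units; within the scatter)). What the carbonyl carries matters more: 2-hydroxy-2-methylbutyl gives lower numbers than oxolan-3-yl (a 3.7-fold lower number from compound 2 to compound 4 (0.57 log units; beyond the scatter)). Likewise, the 1-hydroxy-1-methylpropyl end of the chain in compound 4 compares well with the 1-acetoxypentyl end in compound 1 (a 5.3-fold lower number from compound 1 to compound 4 (0.73 log units; beyond the scatter)).

On these data alone, how an amine or a carboxylic acid on this chain would behave remains open. No supporting data explain these differences.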